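A few compounds are considered here, and "the series" means these few. Any claim that something is new, unique, unknown or untested is made for them only; others in the source may bear on it.

Two compounds of this series have been taken into a functional assay on MCF7 cells (Homo sapiens) for cytotoxicity, read by sulforhodamine B assay, with a stated time of 48 h, in the presence of a further agent that is not named here; a higher number here means a weaker inhibitor of growth, a lower number a stronger inhibitor of growth. There, compound 1 `Cc1nn(-c2ccccc2)c(Oc2ccc(-c3nc4cc([N+](=O)[O-])ccc4[nH]3)cc2)c1/C=N/NC(N)=S` gives > 100000 nM, which is a limit of the assay and not a number. Compound 2 `Cc1nn(-c2ccccc2)c(Oc2ccc(-c3nc4cc(C(N)=O)ccc4[nH]3)cc2)c1/C=N/Nc1ccc([N+](=O)[O-])cc1` offers no number either, as the entry for compound 2 reads "not determined" (no result reported), so it has no place on the scale.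

Compound 3 `Cc1nn(-c2ccccc2)c(Oc2ccc(-c3nc4cc(C(N)=O)ccc4[nH]3)cc2)c1/C=N/NC(N)=S` departs from compound 2 in a single place, on an amine nitrogen whose other neighbours are a double-bonded nitrogen: a group of 3 heavy atoms (1 carbon, 1 nitrogen, 1 sulfur; no ring) in place of a group of 9 heavy atoms (6 carbon, 1 nitrogen, 2 oxygen; one six-membered aromatic ring of carbon only), on an amine nitrogen. The 4-nitrophenyl leaves, and the smaller group without a ring takes its place. Compound 1 carries that same smaller group on the same nitrogen, though the rest of its structure is not identical to that of compound 3.

With no value for compound 2, no size or direction can be expected for this step in this assay. Among the measured compounds shown here, the only guide is the reading for compound 1, so weak inhibition of growth is expected, and a result reported only as a limit remains quite possible. The estimated value for compound 3 is 30000 nM, with an expected range from 3000 nM to 100000 nM.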

Compound 3, concentration for 50% growth inhibition: > 100000 nM
Compound 3: no number, only a limit (the forecaster's own chance of this, stated with the estimate: 45%); middle value at least 3.3-fold (0.52 log units) from the limit.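

In this assay compound 3 gives > 100000 nM as a limit of the assay and not a number, so no new step can be read from compound 1 or compound 2 to compound 3. The compounds shown leave open whether carbamoyl in place of nitro, or the departure of the 4-nitrophenyl, changes inhibition of growth at all.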